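The source may report more compounds than this note shows. Statements on the series, on what has been measured and on what is new or still open speak of the compounds shown alone.

Compound 1 `C=CCn1c(=O)/c(=C\c2cccc(Cl)c2)[nH]c(=O)/c1=C\c1ccccc1OC` in a functional assay on MCF7 cells (Homo sapiens) for cytotoxicity, read by CCK-8 assay, with a stated time of 72 h (a higher number here means a weaker inhibitor, a lower number a stronger inhibitor), gives 5200 nM, the lower of the two numbers available; compound 2 `COc1ccccc1/C=c1/[nH]c(=O)/c(=C\c2ccccc2OC)n(C)c1=O` in this assay gives 9000 nM, which lies within the scatter of compound 1. Compound 3 `C=CCn1c(=O)/c(=C\c2ccccc2Cl)[nH]c(=O)/c1=C\c1ccccc1OC` is not yet measured. It differs from compound 1 by 2-chlorophenyl in place of 3-chlorophenyl on a double-bonded chain carbon bound to an aromatic carbon. Within the data shown here, no measured pair shows what this change does, so for compound 3 no step beyond the scatter is expected in either direction, and the step of a 1.0-fold lower number from compound 1 to compound 3 (0.02 log units; within the scatter) is given as an estimate only. Compound 3 is expected to give about 5000 nM, within a range from 2000 nM to 13000 nM.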

Compound 3, half-maximal inhibitory concentration: 4700 nM
Compound 3: the middle estimate sits 1.1-fold (0.03 log units) above what was measured; low and high end bracket the measured number.
By their numbers in this assay, from the lowest: compounds 3, 1 and 2 (each within the scatter of the next).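

In this assay, 2-chlorophenyl in place of 3-chlorophenyl on a double-bonded chain carbon bound to an aromatic carbon gives a 1.1-fold lower number from compound 1 to compound 3 (0.04 log units; within the scatter) and thus no change that can be told from the scatter. This is the first pair shown that differs in one place, and at this position the two chlorophenyl groups are not told apart by the read-out. No measured property bears on this result.

The compounds shown leave open whether an amine or a carboxylic acid in place of the chlorine would move the number beyond the scatter.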